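Adding a Cyano Group: Expected Effect on Cell Toxicity

The source may hold more compounds than are shown below. What is called first, only, known or untested is meant among the compounds shown, and "the series" means these compounds.

Measured compounds in an ADME assay on NIH3T3 cells (Mus musculus) for cytotoxicity, read by XTT assay, with a stated time of 24 h; on this read-out higher numbers stand for weaker inhibition and lower numbers for stronger inhibition:

Compound 1 `Fc1ccc(C2CC(c3ccc(Cl)s3)=NN2c2nc(-c3ccccc3)cs2)cc1` gives > 500 ug/mL, which is a limit of the assay and not a number.

Compound 2 `Cc1ccc(C2=NN(c3nc(-c4ccc(S(C)(=O)=O)cc4)cs3)C(c3ccc(F)cc3)C2)s1` gives 374 ug/mL.

Compound 1 therefore stands at the limit of > 500 ug/mL in this assay, at which 1 of the 2 values shown sits, so only a limit is known for it. For the measured compounds named here, compound 2 is the one compound of the two with a numerical reading, and the two readings cannot be ordered against each other beyond the fact that one is a limit.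

Compound 3 `N#Cc1ccc(-c2csc(N3N=C(c4ccc(Cl)s4)CC3c3ccc(F)cc3)n2)cc1` has not yet been tested. It differs from compound 1 by cyano in place of hydrogen on an aromatic carbon. Going by the values given here, no two measured compounds differ from each other in a single place, so no measured step shows what a change of this kind does in this assay.

The expectation for compound 3 is that the step from compound 1 will be small, an at least 1.1-fold lower number from compound 1 to compound 3 (0.04 log units; that floor lies within the scatter), and not beyond the usual scatter in either direction. On that basis compound 3 is estimated to give 450 ug/mL in this assay, with an expected range from 220 ug/mL to 700 ug/mL.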

Compound 3, half-maximal inhibitory concentration: > 500 ug/mL
Compound 3: only a limit was reported; the forecaster's own chance of this, stated with the estimate: 50%; at least 1.1-fold (0.04 log units) between middle value and limit.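

Compound 3, like compound 1, gives only a limit and not a number in this assay, so no step can be read between these two compounds: the limit of > 500 ug/mL in this assay, at which 2 of the 3 values shown sit.

The compounds shown leave open whether cyano in place of hydrogen on an aromatic carbon changes the reading at all, and if so, in which direction and by how much.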